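A few compounds are considered here, and "the series" means these few. Any claim that something is new, unique, unknown or untested is made for them only; others in the source may bear on it.

Measured so far in a functional assay on thoracic aorta (Rattus norvegicus) for inhibition; a higher number here means that more compound is needed for the effect, a lower number that less compound is needed:

compound 1, `CC1(C)CC(NC(=S)Nc2ccc(C#N)cc2)c2cc(NS(C)(=O)=O)ccc2O1`: 11600 nM
compound 2, `CC1(C)CC(NC(=S)Nc2cccc(Cl)c2)c2cc(NS(C)(=O)=O)ccc2O1`: 9800 nM
compound 3, `CCS(=O)(=O)Nc1ccc2c(c1)C(NC(=O)Nc1ccc(C#N)cc1)CC(C)(C)O2`: 11800 nM

Compound 1 and compound 2 differ in one place, (3-chlorophenyl in place of 4-cyanophenyl on an amide-type nitrogen). The step is a 1.2-fold lower number from compound 1 to compound 2 (0.07 log units; within the scatter), so the two values cannot be told apart. Compound 3 carries a different core; the difference between the core of compound 1 and the core of compound 3 is not broken down here. Its value in this assay sits within the scatter of the values of compound 1 and compound 2, so nothing separates the three measured compounds.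

Compound 4, `CCS(=O)(=O)Nc1ccc2c(c1)C(NC(=O)Nc1cccc(Cl)c1)CC(C)(C)O2`, is not yet measured. It stands to compound 3 as compound 2 stands to compound 1: 3-chlorophenyl in place of 4-cyanophenyl on an amide-type nitrogen. The place is not the same word for word: in compound 1 the amide-type nitrogen has a thiocarbonyl carbon as its other neighbour, in compound 3 a carbonyl carbon, so this is the same kind of change, not the same change.

For compound 4 in this assay a step of the size of a 1.2-fold lower number from compound 1 to compound 2 (0.07 log units; within the scatter) is expected, that is a 1.2-fold lower number from compound 3 to compound 4 (0.07 log units; within the scatter), resting on that one pair only. The estimate for compound 4 is 10000 nM, between 5000 nM and 20000 nM.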

Compound 4, half-maximal effective concentration: 17200 nM
The estimate for compound 4 lay 1.7-fold (0.24 log units) below the measured number; the range from low to high includes it.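

In this assay, among these compounds, 3-chlorophenyl in place of 4-cyanophenyl on an amide-type nitrogen gives a 1.5-fold higher number from compound 3 to compound 4 (0.16 log units; within the scatter), so on the core of compound 3 this step cannot be told from no step at all. Set beside the same change on the core of compound 1, the two steps cannot be told apart, and nothing here marks the change as behaving differently on the two cores: the same change on two cores in this assay, a 1.2-fold lower number (0.07 log units; within the scatter) from compound 1 to compound 2 and a 1.5-fold higher number (0.16 log units; within the scatter) from compound 3 to compound 4, 1.7-fold (0.24 log units) apart, within the scatter of two such steps

Among the compounds shown here, this does not show that a real effect of the change carries from one core to the other: neither step stands clear of the scatter, only two pairs are available, and their agreement says no more than that no effect of this change can be seen on either core.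

On these data alone, only 4-cyanophenyl and 3-chlorophenyl appear on the amide-type nitrogen, so it remains open whether an amine, a carboxylic acid or a longer alkyl chain in that place would shift the number beyond the scatter. Also open, as far as these compounds go, is whether a sulfonyl substituent longer than ethyl would do so.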